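This account rests on a few compounds, and the source may have more. Where it says the series, first, only, none or still open, it means among the compounds named here.

Compound 1 `COC[C@H]1C[C@@](CC(C)C)(C(=O)O)N(C(=O)c2ccc(C(C)(C)C)c(OC)c2)[C@H]1C(N)=O` gives > 120000 nM in an ADME assay on Huh-5-2 cells (Homo sapiens) for cytotoxicity, with a stated time of 3 days (on this read-out higher numbers stand for lower toxicity in this test and lower numbers for higher toxicity in this test), which is a limit of this assay.
Compound 2 `CC[C@H]1[C@@H](COC)C[C@@](CC(C)C)(C(=O)O)N1C(=O)c1ccc(C(C)(C)C)c(OC)c1` gives 200000 nM in this assay.
Compound 3 `C=CCOC[C@H]1[C@@H](COC)C[C@@](CC(C)C)(C(=O)O)N1C(=O)c1ccc(C(C)(C)C)c(OC)c1` gives > 120000 nM in this assay, again a limit.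

Compound 3 therefore stands only at a limit, and (the limit of > 120000 nM in this assay, at which 2 of the 3 values shown sit). Compound 4 `COC[C@H]1C[C@@](CC(C)C)(C(=O)O)N(C(=O)c2ccc(C(C)(C)C)c(OC)c2)[C@H]1COC(=O)OC` is not yet measured; it differs from compound 3 by methoxycarbonyl in place of allyl on an oxygen on a saturated carbon. The measured steps that bear on such changes at the same ring position are a step that the two limits leave unreadable from compound 1 to compound 3, a step that the limit leaves unreadable from compound 2 to compound 3 and a step that the limit leaves unreadable from compound 1 to compound 2, none of which has a readable size. No step beyond the scatter is therefore expected, and the result is again likely a limit. Compound 4 is expected to give 150000 nM, with a range from 60000 nM to 400000 nM. The expected step is thus a step that the limit leaves unreadable from compound 3 to compound 4, within the scatter.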

Compound 4, half-maximal cytotoxic concentration: > 120000 nM
Compound 4: no number, only a limit; the forecaster's own chance of this, stated with the estimate: 70%; the middle value lies beyond the limit too.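

Compound 4 returns only a limit, as do compound 1 and compound 3, so no step to or from compound 4 can be read: the limit of > 120000 nM in this assay, at which 3 of the 4 values shown sit.

As far as these compounds go, whether methoxycarbonyl in place of allyl changes the read-out at all remains open.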